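Halogenated benzyl lactones in a cytotoxicity assay

The compounds below may be only part of what the source reports. "The series", "measured", "known", "first", "only" and "open" are said of these compounds alone.

Measured compounds:
Compound 1, `CCCCCCCOc1cccc(C[C@H]2C(=O)OC[C@@H]2Cc2ccccc2)c1`, in a functional assay on HL-60 cells (Homo sapiens) for cytotoxicity, read by WST assay, with a stated time of 48 h (on this read-out lower numbers stand for an effect already at smaller amounts and higher numbers for an effect only at larger amounts of compound), gives 81000 nM.
Compound 2, `O=C1OC[C@H](Cc2ccccc2)[C@H]1Cc1cccc(F)c1`, in this assay gives 75000 nM.

Compound 2 holds the lowest of the two numbers shown in this assay, but its nearest neighbour is compound 1, and the single measured step, a 1.1-fold lower number from compound 1 to compound 2 (0.03 log units; within the scatter), is within the scatter, so no order between compound 2 and compound 1 can be claimed.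

The unmeasured compound 3, `O=C1OC[C@H](Cc2ccccc2)[C@H]1Cc1ccc(Cl)cc1`, differs from compound 2 by 4-chlorophenyl in place of 3-fluorophenyl on a saturated chain carbon bound to a saturated ring carbon. Within the data shown here, the only step on record that bears on this change is the one on the same aromatic ring, a 1.1-fold lower number from compound 1 to compound 2 (0.03 log units; within the scatter), where a much larger exchange of substituents moved the number no further than the scatter. Exchanging one halogen for another, with the same count of heavy atoms and no change in donors or acceptors, is a smaller alteration than that. Compound 3 is therefore expected to show in this assay a step of a 1.1-fold lower number from compound 2 to compound 3 (0.03 log units; within the scatter), that is, no step beyond the scatter. The estimate for compound 3 is 70000 nM, with a range from 30000 nM to 160000 nM.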

Compound 3, half-maximal effective concentration: 36000 nM
Compound 3: the middle estimate sits 1.9-fold (0.29 log units) above what was measured, and the stated range covers the measured number.
By their numbers in this assay, from the lowest: compound 3; then compounds 2 and 1 (each within the scatter of the next).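

In this assay the exchange on this aromatic ring gives a step beyond the scatter (a 2.1-fold lower number from compound 2 to compound 3 (0.32 log units; beyond the scatter)), though a modest one, whereas the earlier step on the same ring (a 1.1-fold lower number from compound 1 to compound 2 (0.03 log units; within the scatter)) stayed within it. At this place, on a saturated chain carbon bound to a saturated ring carbon, the number therefore responds to a swap between 3-fluorophenyl and 4-chlorophenyl, two groups with the same count of heavy atoms and with no hydrogen-bond donors or acceptors. Nothing on record bears on why the number moved with this exchange.

The exchange alters both the halogen and its place on the ring, and the compounds shown do not separate the two, so it stays open whether the chlorine itself or its new place goes with the step. They also leave open how a bromine, an amine or a carboxylic acid on this ring would read in this assay, and whether any such group would move the number further than compound 3 does.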